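The source may hold more compounds than are shown below. What is called first, only, known or untested is meant among the compounds shown, and "the series" means these compounds.

In a functional assay on MV4-11 cells (Homo sapiens) for antiproliferative activity, read by CCK-8 assay, with a stated time of 72 h (on this read-out higher numbers stand for weaker inhibition and lower numbers for stronger inhibition), compound 1 (`Cn1cc(-c2ccccc2Oc2ccccc2)c2cc(C(=O)NCCCCCCC(=O)NO)[nH]c2c1=O`) gives 180 nM. Compound 2 (`Cn1cc(-c2ccccc2F)c2cc(C(=O)NCc3ccc(C(=O)Nc4ccccc4N)cc3)[nH]c2c1=O`) gives 230 nM, within the usual scatter of compound 1, while compound 3 (`Cn1cc(-c2ccccc2Oc2ccccc2)c2cc(C(=O)NCc3ccc(C(=O)NO)cc3)[nH]c2c1=O`) gives 570 nM. Still unmeasured is compound 4 (`Cn1cc(-c2ccccc2Oc2ccccc2)c2cc(C(=O)NCCCCC(=O)Nc3ccccc3N)[nH]c2c1=O`), where (2-aminophenyl)carbamoyl replaces 2-(hydroxycarbamoyl)ethyl on a saturated chain carbon, four bonds along the chain from an amide-type nitrogen: (2-aminophenyl)carbamoyl in place of 2-(hydroxycarbamoyl)ethyl on a saturated chain carbon, four bonds along the chain from an amide-type nitrogen. For the measured compounds named here, the one measured step altering this chain is modest: a 3.2-fold higher number from compound 1 to compound 3 (0.50 log units; beyond the scatter). Compound 2 also carries (2-aminophenyl)carbamoyl but differs elsewhere, so its 230 nM offers only loose guidance. A modest rise is therefore expected, an estimated 2.3-fold higher number from compound 1 to compound 4 (0.37 log units; beyond the scatter). For compound 4 the expected value is 420 nM, with an estimated range of 130 nM to 1400 nM.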

Compound 4, half-maximal inhibitory concentration: 240 nM
Beside the measured number, compound 4's estimate is 1.8-fold (0.24 log units) above it, within the range that was stated.
By their numbers in this assay, from the lowest: compounds 1, 2 and 4 (each within the scatter of the next); then compound 3.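

In this assay the change at this chain end gives a 1.3-fold higher number from compound 1 to compound 4 (0.12 log units; within the scatter) and so leaves the number within the scatter. At this position, on the core of compound 1, the 2-(hydroxycarbamoyl)ethyl end can therefore give way to (2-aminophenyl)carbamoyl, with its six-membered aromatic ring, without a readable loss of activity. No available evidence explains why these two end groups read alike.

Still open, as far as these compounds go, is whether a carboxylic acid or a simple amine at the chain end would read the same. Also open, from the compounds shown here alone, is how a longer chain carrying (2-aminophenyl)carbamoyl would compare.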